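Swapping an amide for a urea on a shared core

The source may hold more compounds than are shown below. What is called first, only, known or untested is meant among the compounds shown, and "the series" means these compounds.

Going by the values given here, the two compounds measured so far share one core and differ in the group that hangs from the amide-type nitrogen. Compound 1, with the structure `COc1cc(Cl)cc(-c2nn(-c3cccc(NC(=O)c4ccc(Cl)c(Cl)c4)c3)cc2-c2ccncc2)c1`, is tested in a functional assay on MOLT-4 cells (Homo sapiens) for inhibition, read by sulforhodamine B assay, with a stated time of 48 h, tested at 10 uM (on this read-out lower numbers stand for a stronger effect and higher numbers for a weaker effect at the one concentration tested), and gives 54.9%. Compound 2, with the structure `COc1cc(Cl)cc(-c2nn(-c3cccc(NC(=O)Nc4cc(C(F)(F)F)cc(C(F)(F)F)c4)c3)cc2-c2ccncc2)c1`, gives in this assay a reading of -24.7%. Of these two numbers, compound 1 holds the higher one, and the gap to compound 2 lies beyond the scatter of the method, so compound 1 shows the weaker effect of the pair.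

Compound 3, with the structure `COc1cc(Cl)cc(-c2nn(-c3cccc(NC(=O)Nc4ccc(Cl)c(Cl)c4)c3)cc2-c2ccncc2)c1`, has not been measured. Its difference from compound 1 is a single change: (3,4-dichlorophenyl)amino in place of 3,4-dichlorophenyl on a carbonyl carbon. The carbonyl is kept, but one more nitrogen, carrying a hydrogen-bond donor, is inserted between it and the dichlorophenyl ring.

Among the compounds with values here, no measured pair tracks exactly this change, so the size of the step is uncertain. The step from compound 1 to compound 3 is expected to be a number 39.9 percentage points lower from compound 1 to compound 3 (beyond the scatter), towards a lower number. Compound 3 is therefore estimated to give 15% in this assay, with a range from -20% to 50%.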

Compound 3, a percentage reported as activity, at one concentration (the size of the read-out at that concentration, not a potency): -16.1%
For compound 3 the middle estimate is 31.1 percentage points above the measured one; measured number inside the range.
By their numbers in this assay, from the lowest: compounds 2 and 3 (each within the scatter of the next); then compound 1.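

Holding the 3,4-dichlorophenyl ring fixed and adding only the amino group on the carbonyl carbon, which turns the amide of compound 1 into the urea of compound 3, gives a large change in this assay: a number 71 percentage points lower from compound 1 to compound 3 (beyond the scatter). The first two compounds could not show this, since they differ in both the link and the ring, whereas this pair isolates the link and shows that it alone moves the reading by far more than the scatter, while the readings of compound 2 at -24.7% and compound 3 at -16.1% lie within the scatter of each other despite their different rings. The data offer no explanation of why this single change has so large an effect.

On these data alone, it remains open whether the added nitrogen must carry its hydrogen, a question that an N-methyl urea would address, or whether a carbamate, with an oxygen at that place, or a thiourea, with sulfur in place of the carbonyl oxygen, would read like compound 3. As far as these compounds go, it is also open how the urea behaves with a plain phenyl ring or with a longer chain, such as a benzyl group, in place of the 3,4-dichlorophenyl ring.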